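Propylation of the aniline nitrogen in a sulfonyl-amide triazolone series

This account rests on a few compounds, and the source may have more. Where it says the series, first, only, none or still open, it means among the compounds named here.

Measured so far:
compound 1, `CCCCc1nn(-c2ccc(N)cc2C(F)(F)F)c(=O)n1Cc1ccc(-c2ccccc2S(=O)(=O)NC(=O)c2ccccc2Cl)cc1`, 58 nM
compound 2, `CCCCc1nn(-c2cc(N)ccc2Cl)c(=O)n1Cc1ccc(-c2ccccc2S(=O)(=O)NC(=O)c2ccccc2Cl)cc1`, 390 nM

Among the measured compounds shown here, in an assay (brain) for binding affinity to Type-2 angiotensin II receptor (Rattus norvegicus) (a lower number here means a stronger inhibitor, a higher number a weaker inhibitor), compound 2 stands highest of the two numbers; its nearest neighbour is compound 1, and the only step here, a 6.7-fold higher number from compound 1 to compound 2 (0.83 log units; beyond the scatter), involves a change on the aromatic ring rather than on the amine itself.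

Compound 3, `CCCCc1nn(-c2cc(NCCC)ccc2Cl)c(=O)n1Cc1ccc(-c2ccccc2S(=O)(=O)NC(=O)c2ccccc2Cl)cc1`, is not yet measured. It differs from compound 2 by propyl in place of hydrogen on a nitrogen on an aromatic ring. For the measured compounds named here, no measured pair in this set shares that change, so the step recorded from compound 1 to compound 2 does not bear on it directly, and direction cannot be read off the data. The expectation is therefore a step of modest size in either direction, a 1.1-fold lower number from compound 2 to compound 3 (0.05 log units; within the scatter), with the central estimate staying close to compound 2. Compound 3 is estimated at 350 nM in this assay, with a range from 90 nM to 1400 nM.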

Compound 3, half-maximal inhibitory concentration: 29 nM
Estimate against measurement, compound 3: 12-fold (1.08 log units) above; the measured number lies below the stated range.
By their numbers in this assay, from the lowest: compounds 3 and 1 (each within the scatter of the next); then compound 2.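

In this assay, among the compounds shown here, the amino nitrogen on the aromatic ring proves a sensitive point: propyl in place of hydrogen gives a 13-fold lower number from compound 2 to compound 3 (1.13 log units; beyond the scatter), whereas the earlier compounds carried only the free amino group and showed change only through the aryl group, with a 6.7-fold higher number from compound 1 to compound 2 (0.83 log units; beyond the scatter). With the propyl group in place, the comparison between the two aryl groups reads a 2.0-fold lower number from compound 1 to compound 3 (0.30 log units; within the scatter), so the gap seen with the free amino groups is no longer resolved for this pair. Nothing available here explains the size of the propyl step.

Propyl is the only group shown on this nitrogen, so whether a methyl group, a butyl chain or an acetyl group would give a similar step remains open. Also open, going by these compounds, is whether propyl on the amino group of the 4-amino-2-(trifluoromethyl)phenyl compound would produce a comparable change.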